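The source may report more compounds than this note shows. Statements on the series, on what has been measured and on what is new or still open speak of the compounds shown alone.

Compound 1 `O=C(O)CCCc1ccc(NCc2cccc(Oc3ccccc3)c2)cc1` gives 1120 nM in a functional assay on CHO cells for agonist activity at Free fatty acid receptor 1 (Homo sapiens); a higher number here means that more compound is needed for the effect, a lower number that less compound is needed. Compound 3 `Cc1nc(-c2ccc(C(F)(F)F)cc2)sc1CNc1ccc(C(C)CC(=O)O)cc1` gives 58.9 nM. For compound 2 `CC(C)(Oc1ccc(NCc2cccc(Oc3ccccc3)c2)cc1)C(=O)O` only a limit is known, < 10000 nM. Among the compounds with values here, the one measured step, a step that the limit leaves unreadable from compound 1 to compound 2, therefore has no readable size, because of the limit of < 10000 nM in this assay, at which 1 of the 3 values shown sits. Compound 4 `CNC(=O)CCc1ccc(NCc2cccc(Oc3ccccc3)c2)cc1` differs from compound 2 in one place: 2-(methylcarbamoyl)ethyl in place of 1-carboxy-1-methylethoxy on an aromatic carbon. Within the data shown here, no measured step covers an exchange of this kind, so none bears directly on it, and the starting point itself is only a limit. The value of compound 4 is therefore estimated with wide room, at 5000 nM, expected between 800 nM and 30000 nM, which would mean a step that the limit leaves unreadable from compound 2 to compound 4.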

Compound 4, half-maximal effective concentration: 49 nM
For compound 4 the middle estimate is 100-fold (2.01 log units) above the measured one; measured number outside the range, below it.
By their numbers in this assay, from the lowest: compounds 4 and 3 (each within the scatter of the next); then compound 1.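

At this position, a carboxylic acid at the chain end is not needed for activity in this assay: methylcarbamoyl in place of carboxymethyl gives a 23-fold lower number from compound 1 to compound 4 (1.36 log units; beyond the scatter). On the shared core, the chain ending in the amide therefore needs less compound than the chain ending in the acid. Compound 2 has only a limit, so its step to compound 4 cannot be read: the limit of < 10000 nM in this assay, at which 1 of the 4 values shown sits.

The compounds shown leave open whether this gain is specific to methylcarbamoyl or would also appear with a primary amide or a tetrazole. They also leave open whether it would carry over to the core of compound 3.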